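The compounds below may be only part of what the source reports. "The series", "measured", "known", "first", "only" and "open" are said of these compounds alone.

Compound 1 `O=c1cc(CNCc2ccc(Cl)cc2)oc2ccc(O)c(O)c12` gives in an ADME assay on Huh-7 cells (Homo sapiens) for cytotoxicity (a higher number here means that more compound is tolerated, a lower number that less compound is tolerated), a value that is only a limit of the assay, > 100000 nM.
Compound 2 `O=c1cc(CNCc2ccc(Br)cc2)oc2ccc(O)c(O)c12` gives in this assay likewise only a limit, > 100000 nM.
Compound 3 `O=c1cc(CNCc2ccc(I)cc2)oc2ccc(O)c(O)c12` gives in this assay 41700 nM.

Among these three, compound 3 is the only one with an actual number: the other two values sit at the limit described by the limit of > 100000 nM in this assay, at which 2 of the 3 values shown sit. The step to compound 4 `O=c1cc(CNCc2ccc(O)cc2)oc2ccc(O)c(O)c12` is hydroxy in place of iodo on an aromatic carbon. Two measured steps lead into compound 3 and so bear on it: an at least 2.3-fold lower number from compound 1 to compound 3 (0.37 log units; beyond the scatter) and an at least 2.3-fold lower number from compound 2 to compound 3 (0.37 log units; beyond the scatter). Both show that, of the three halogens, only the iodo compound gave a readable number, while the smaller halogens sat at the limit. Among the measured compounds shown here, exchanging iodo for a hydroxy group is a different kind of change, and no measured step covers it directly; the nearest guidance is that moving away from iodo has so far meant a higher number. Compound 4 is therefore expected to give about 100000 nM in this assay, with a range from 40000 nM to 300000 nM. That estimate means an expected step of a 2.4-fold higher number from compound 3 to compound 4 (0.38 log units; beyond the scatter).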

Compound 4, half-maximal cytotoxic concentration: 62700 nM
Compound 4: the middle estimate sits 1.6-fold (0.20 log units) above what was measured; the measured number falls inside the stated range.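

A hydroxy group on this carbon of the aromatic ring, which adds a hydrogen-bond donor and acceptor that iodo lacks, gives a number in this assay that cannot be told apart from the iodo one: a 1.5-fold higher number from compound 3 to compound 4 (0.18 log units; within the scatter). A readable number in this assay is therefore not confined to iodo among the groups shown here. Compound 1 and compound 2 hold only limits, so the comparisons with them give only floors within the scatter, an at least 1.5-fold lower number from compound 2 to compound 4 (0.20 log units; that floor lies within the scatter) and an at least 1.5-fold lower number from compound 1 to compound 4 (0.20 log units; that floor lies within the scatter), and a real gap to compound 4 remains unproven: the limit of > 100000 nM in this assay, at which 2 of the 4 values shown sit.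

The compounds shown leave open whether an amine, a carboxylic acid or a longer chain such as methoxy at this place would give a similar number. They also leave open how far the true values of compound 1 and compound 2 lie from that of compound 4.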